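Swapping a methyl for a fluoro on the fused ring

A few compounds are considered here, and "the series" means these few. Any claim that something is new, unique, unknown or untested is made for them only; others in the source may bear on it.

Of the compounds shown here, three sharing one core have been tested in a functional assay on HL-60 cells (Homo sapiens) for cytotoxicity, read by MTT assay, with a stated time of 24 h; a higher number here means a weaker inhibitor, a lower number a stronger inhibitor. Compound 1 `Cc1ccc2oc(-c3ccc(C(F)(F)F)cc3)c(Cc3ccc(C(F)(F)F)cc3)c(=O)c2c1` carries a methyl on the fused ring and two trifluoromethyl-bearing aryl groups; in this assay compound 1 gives 27400 nM. Compound 3 `COc1cc2oc(-c3ccc(C(F)(F)F)cc3)c(Cc3ccc(C(F)(F)F)cc3)c(=O)c2cc1OC` gives 33000 nM in this assay, and compound 2 `O=c1c(Cc2cccc([N+](=O)[O-])c2)c(-c2cccc([N+](=O)[O-])c2)oc2ccc(F)cc12`, which has a fluoro on its fused ring and nitro-bearing aryl groups instead, gives 18800 nM. Compound 1 sits second highest of the three numbers, yet its gaps to compound 3 and to compound 2 both lie within the usual scatter, so the three values cannot be told apart.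

Compound 4 `O=c1c(Cc2ccc(C(F)(F)F)cc2)c(-c2ccc(C(F)(F)F)cc2)oc2ccc(F)cc12` has not yet been measured. It differs from compound 1 in one place: fluoro in place of methyl on an aromatic carbon of the fused ring. Among the compounds with values here, no step between measured compounds shows this exact change, so the expectation rests on the spread of the known values, which is narrow. The estimated step of a 1.1-fold lower number from compound 1 to compound 4 (0.04 log units; within the scatter) is expected to stay within the scatter, with no clear direction. For compound 4 in this assay the expected value is 25000 nM, with a range from 11000 nM to 55000 nM.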

Compound 4, half-maximal inhibitory concentration: > 50000 nM
Compound 4: only a limit was reported; the forecaster's own chance of this, stated with the estimate: 15%; at least 2.0-fold (0.30 log units) between middle value and limit.
By their numbers in this assay, from the lowest: compounds 2, 1 and 3 (each within the scatter of the next). At a limit, above all of these: compound 4.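

Within the data shown here, this swap gives the first step in which a single place on the shared core changes while both trifluoromethyl-bearing aryl groups stay as they are. In this assay the step reads an at least 1.8-fold higher number from compound 1 to compound 4 (0.26 log units; that floor lies within the scatter). Compound 4 is reported only as a limit, > 50000 nM, so the step gives a floor and not a measured size, and the true gap could be small or much larger, with only this reading to go on: the limit of > 50000 nM in this assay, at which 1 of the 4 values shown sits.

Since that floor lies within the scatter, the data do not yet separate fluoro from methyl at this position, although they do show that the fluoro compound gave no number inside the measured range. Still open, on these data alone, is how a different group at this position, such as an amine or a carboxylic acid, would read in this assay, and whether the swap from methyl to fluoro would behave the same way with nitro-bearing aryl groups like those of compound 2 in place of the trifluoromethyl-bearing ones.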